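The compounds below may be only part of what the source reports. "The series", "measured", "known", "first", "only" and "open" are said of these compounds alone.

Measured compounds:
- compound 1 `O=C1/C(=C/c2ccc(O)c(O)c2)COc2ccccc21` gives 141000 nM in an assay on isolated protein for inhibition of Amine oxidase [flavin-containing] B (Homo sapiens); on this read-out lower numbers stand for stronger inhibition and higher numbers for weaker inhibition
- compound 2 `CC(C)=CCOc1ccc(C(=O)/C=C/c2ccccc2)c(O)c1` gives 18600000 nM in this assay

For the measured compounds named here, compound 2 stands at the highest of the two numbers measured, and its nearest neighbour, compound 1, sits far below it, well beyond the scatter; no single-point step connects them, so only the two values themselves can be compared.

Compound 3 `CC(C)=CCOc1ccc(C(=O)/C=C/c2ccc(C)cc2)c(O)c1` is the next compound to be measured in this assay. The change from compound 2 to compound 3 is methyl in place of hydrogen on an aromatic carbon — methyl in place of hydrogen on an aromatic carbon, para to a large group; cut one bond further out it reads phenyl to 4-methylphenyl.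

Going by the values given here, with no comparable step among the measured compounds, the expectation is a step of a 1.6-fold lower number from compound 2 to compound 3 (0.19 log units; within the scatter) for compound 3, small and within the scatter. Compound 3 is estimated at 12000000 nM, within 3000000 nM to 50000000 nM.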

Compound 3, half-maximal inhibitory concentration: 1020000 nM
Compound 3: middle estimate off by 12-fold (1.07 log units), on the high side; the whole stated range lies above it.
By their numbers in this assay, from the lowest: compound 1; then compound 3; then compound 2.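

In this assay the aromatic carbon para to a large group proves sensitive to substitution: methyl in place of hydrogen gives an 18-fold lower number from compound 2 to compound 3 (1.26 log units; beyond the scatter) for a change of only one heavy atom. For the compounds shown here, this is the only single-place step so far, and it shows that the phenyl end of the shared core is not indifferent to what it carries. Nothing measured here bears on why the step is this large.

As far as these compounds go, whether the same direction holds for a longer chain such as ethyl, or for a methoxy group or a chlorine atom on the same carbon, remains open. Also open, from the compounds shown here alone, is whether an amine or a carboxylic acid there would move the number the same way, and whether methyl elsewhere on this ring would give a comparable step.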